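Moving the Hydroxyl Around the Amide Ring

A few compounds are considered here, and "the series" means these few. Any claim that something is new, unique, unknown or untested is made for them only; others in the source may bear on it.

Measured so far:
- compound 1, `CC1=C(/C=C/C(C)=C/C=C/C(C)=C\C(=O)NCc2ccc(F)cc2)C(C)(C)CCC1n1ccnc1`: in a functional assay on SK-BR-3 cells (Homo sapiens) for inhibition, read by MTT assay (a lower number here means a stronger inhibitor of growth, a higher number a weaker inhibitor of growth), compound 1 gives 5500 nM
- compound 2, `CC1=C(/C=C/C(C)=C/C=C/C(C)=C\C(=O)Nc2ccccc2O)C(C)(C)CCC1n1ccnc1`: in this assay compound 2 gives 3890 nM

Compound 2 sits right beside compound 1 on these two numbers: the step of a 1.4-fold lower number from compound 1 to compound 2 (0.15 log units; within the scatter) is the only one measured, and it is too small to separate the two compounds from each other.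

Compound 3, `CC1=C(/C=C/C(C)=C/C=C/C(C)=C\C(=O)Nc2ccc(O)cc2)C(C)(C)CCC1n1ccnc1`, keeps the whole core of compound 2 and changes only the ring on the amide nitrogen: 4-hydroxyphenyl in place of 2-hydroxyphenyl on an amide-type nitrogen. The same atoms are present in both compounds; only the point at which the hydroxyl sits on the ring moves.

For the measured compounds named here, no measured step bears directly on this move. Going by the values given here, the one step available, from compound 1 to compound 2, replaced the entire ring substituent and still stayed within the scatter, which gives no hint that a smaller rearrangement on the same ring would move the number more. The expectation is therefore a step of a 1.0-fold higher number from compound 2 to compound 3 (0.01 log units; within the scatter) in this assay, that is, nothing beyond the scatter. Compound 3 is estimated at 4000 nM, with a range from 1500 nM to 12000 nM.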

Compound 3, concentration for 50% growth inhibition: 3890 nM
The estimate for compound 3 lay 1.0-fold (0.01 log units) above the measured number, within the range that was stated.
By their numbers in this assay, from the lowest: compounds 2, 3 and 1 (each within the scatter of the next).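

On this amide nitrogen, where the hydroxyl sits on the ring does not register in this assay: 4-hydroxyphenyl in place of 2-hydroxyphenyl gives no change at the digits printed from compound 2 to compound 3 (within the scatter). Replacing the whole group, with 4-hydroxyphenyl in place of 4-fluorobenzyl, gives a 1.4-fold lower number from compound 1 to compound 3 (0.15 log units; within the scatter), so all three compounds now stand within the scatter of one another, whether the group on this nitrogen carries a hydroxyl at either of two ring positions or is a fluorinated benzyl. Nothing available here explains why these groups read alike, as the numbers come with no supporting data on the compounds.

From the compounds shown here alone, all three groups carry a single aromatic ring of carbon on the amide nitrogen, so it remains open whether this position would respond to something quite different, such as an amine, a carboxylic acid or a longer chain in place of that ring. Also open, going by these compounds, is whether a methoxy group in place of the hydroxyl would read any differently, and whether the same picture would hold in a cell line other than this one.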